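A few compounds are considered here, and "the series" means these few. Any claim that something is new, unique, unknown or untested is made for them only; others in the source may bear on it.

Measured in a functional assay on KB cells (Homo sapiens) for cytotoxicity, read by MTT assay, with a stated time of 72 h; a lower number here means a stronger inhibitor, a higher number a weaker inhibitor:
Compound 1 `COc1ccc(S(=O)(=O)c2nc3ccccc3nc2N2CCCC2)cc1`: > 50000 nM
Compound 2 `Cc1ccc(S(=O)(=O)c2nc3ccccc3nc2N2CCc3ccccc3C2)cc1`: 32100 nM

The entry for compound 1, > 50000 nM, is a limit of the assay and not a number. For the measured compounds named here, compound 2, at 32100 nM, therefore holds the only numeric value. Compound 3 `COc1ccc(S(=O)(=O)c2nc3ccccc3nc2N2CCc3ccccc3C2)cc1` differs from compound 2 by methoxy in place of methyl on an aromatic carbon. No measured step sizes this change, so the expectation rests on compound 2 at 32100 nM, with no shift beyond the scatter in this assay in either direction. The expected step of a 1.1-fold higher number from compound 2 to compound 3 (0.04 log units; within the scatter) is small. Compound 3 is estimated at 35000 nM, with an expected range of 15000 nM to 50000 nM.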

Compound 3, half-maximal inhibitory concentration: > 50000 nM
Compound 3 ended at the assay's limit; the forecaster's own chance of this, stated with the estimate: 30%; at least 1.4-fold (0.15 log units) between middle value and limit.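

In this assay, for the compounds shown here, the change from 4-methylphenyl to 4-methoxyphenyl gives the first step at this position, with an at least 1.5-fold higher number from compound 2 to compound 3 (0.19 log units; that floor lies within the scatter) as the result. With compound 3 at a limit, only that floor is known, and it does not separate the change from the scatter. The step between the pyrrolidin-1-yl and 1,2,3,4-tetrahydroisoquinolin-2-yl groups cannot be read because compound 1 and compound 3 both end at the same limit: the limit of > 50000 nM in this assay, at which 2 of the 3 values shown sit.

Still open, as far as these compounds go, is whether chlorine or an amine at this position would give a lower number than compound 2 does.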